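Cytotoxicity notes: aryl carbonyl change on the shared core

This account rests on a few compounds, and the source may have more. Where it says the series, first, only, none or still open, it means among the compounds named here.

Compound 1 `O=C1c2ccccc2C(=O)N1CCOC(=S)N(C(=O)c1cccc([N+](=O)[O-])c1)c1ccc(Cl)cc1` is the reference point of this small set. Within the data shown here, in an ADME assay on MT4 cells (Homo sapiens) for cytotoxicity, read by MTT assay (on this read-out lower numbers stand for higher toxicity in this test and higher numbers for lower toxicity in this test), compound 1 gives 18000 nM, the lowest of the three numbers known so far. Compound 2 `Cc1ccc(N(C(=O)c2cccc([N+](=O)[O-])c2)C(=S)OCCN2C(=O)c3ccccc3C2=O)cc1` gives 100000 nM in this assay, and compound 3 `O=C1c2ccccc2C(=O)N1CCOC(=S)N(C(=O)c1cc(F)ccc1F)c1ccc(Cl)cc1` gives 54000 nM. Both known steps move away from compound 1 upward: a 5.6-fold higher number from compound 1 to compound 2 (0.74 log units; beyond the scatter), and a 3.0-fold higher number from compound 1 to compound 3 (0.48 log units; beyond the scatter).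

Compound 4 `O=C1c2ccccc2C(=O)N1CCOC(=S)N(C(=O)c1ccc([N+](=O)[O-])cc1Cl)c1ccc(Cl)cc1` has not yet been measured. It differs from compound 1 as follows: 2-chloro-4-nitrophenyl in place of 3-nitrophenyl on a carbonyl carbon. Among the measured compounds shown here, the step that bears on this is the one from compound 1 to compound 3, which also exchanges the aryl group on the carbonyl carbon and gave a 3.0-fold higher number from compound 1 to compound 3 (0.48 log units; beyond the scatter). For the measured compounds named here, the change from compound 1 to compound 2 is at another place and informs only that the core tolerates modest upward movement. A modest rise, or none beyond the scatter, is therefore expected; the direction is taken from the step from compound 1 to compound 3, although a single step is a thin basis.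

For compound 4 the estimate is 30000 nM, with a range of 12000 nM to 80000 nM, which corresponds to an expected 1.7-fold higher number from compound 1 to compound 4 (0.22 log units; within the scatter).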

Compound 4, half-maximal cytotoxic concentration: 19000 nM
The estimate for compound 4 lay 1.6-fold (0.20 log units) above the measured number; low and high end bracket the measured number.
By their numbers in this assay, from the lowest: compounds 1 and 4 (each within the scatter of the next); then compounds 3 and 2 (each within the scatter of the next).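

On the carbonyl carbon, 2-chloro-4-nitrophenyl in place of 3-nitrophenyl leaves the number in this assay without a change beyond the scatter: a 1.1-fold higher number from compound 1 to compound 4 (0.02 log units; within the scatter). A change of aryl group at this place therefore does not raise the number in every case, and the group that enters matters, as the exchange of 2,5-difluorophenyl for 2-chloro-4-nitrophenyl shows: a 2.8-fold lower number from compound 3 to compound 4 (0.45 log units; beyond the scatter). Nothing available explains this difference between the two aryl groups.

As far as these compounds go, it remains open whether a carbonyl substituent without an aromatic ring, such as cyclohexyl, or an aryl group carrying an amine or a carboxylic acid, would shift the number at this place. Also open, from the compounds shown here alone, is whether methyl in place of chloro on the other aromatic ring would give the same rise with 2-chloro-4-nitrophenyl on the carbonyl carbon as it did with 3-nitrophenyl.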